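Removing one methyl from compound 2

This account rests on a few compounds, and the source may have more. Where it says the series, first, only, none or still open, it means among the compounds named here.

- compound 1 `O=C(c1ccc(NCc2cncn2Cc2ccc(-c3ccccc3)cc2)cc1-c1ccccc1)N1CCCCC1` gives > 1000 nM
- compound 2 `Cc1cccc(-c2cccc(NCc3cncn3Cc3ccccc3)c2)c1C` gives > 1000 nM

In a toxicity assay on NIH3T3 cells (Mus musculus) for cytotoxicity, read by resazurin assay (a lower number here means that less compound is needed, a higher number that more compound is needed for the effect), compound 2 gives > 1000 nM as a limit of the assay, not a number. Among the compounds with values here, compound 1 sits at the same limit, so the limit of > 1000 nM in this assay, at which 2 of the 2 values shown sit, describes every value available so far. Within the data shown here, neither compound has an exact number, and no measured step links two close relatives.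

Compound 3 `Cc1ccccc1-c1cccc(NCc2cncn2Cc2ccccc2)c1` turns the 2,3-dimethylphenyl of compound 2 into 2-methylphenyl, with hydrogen in place of methyl on an aromatic carbon in the structure. The expected step that the limit leaves unreadable from compound 2 to compound 3 is none beyond the scatter, with no direction favoured. This expectation rests on compound 2 with its > 1000 nM and on the small size of the change. For compound 3 the estimated value is 1500 nM and the expected range runs from 600 nM to 5000 nM in this measurement.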

Compound 3, half-maximal effective concentration: > 1000 nM
Compound 3 was reported as a limit; the forecaster's own chance of this, stated with the estimate: 80%; the middle value does not contradict the limit.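

In this assay compound 3 gives > 1000 nM, a limit of the assay and not a number. Compound 2 also sits at a limit, so the step between compound 2 and compound 3 cannot be read. The compounds shown leave open the exact concentration each one needs for the effect, and whether swapping the methyl for hydrogen changes it: the limit of > 1000 nM in this assay, at which 3 of the 3 values shown sit.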